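Moving a Methoxy Group on an Inactive Amide

This account rests on a few compounds, and the source may have more. Where it says the series, first, only, none or still open, it means among the compounds named here.

Compound 1 `COc1ccc(-c2c(Br)c(=O)c3c(OC)cc(OC)cc3n2S(=O)(=O)c2ccc(OC)cc2)cc1` gives 49700 nM in an ADME assay on BJ cells (Homo sapiens) for antiproliferative activity, with a stated time of 72 h; on this read-out lower numbers stand for an effect already at smaller amounts and higher numbers for an effect only at larger amounts of compound.
Compound 2 `COC(=O)c1cc(=O)c2c(OC)cc(OC)cc2n1C` reaches only a limit in this assay, namely > 37900 nM.
Compound 3 `COc1cc(OC)c2c(=O)cc(C(=O)Nc3cc(C(F)(F)F)ccc3Oc3ccccc3OC)[nH]c2c1` likewise reaches only a limit in this assay, namely > 53400 nM.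

Compound 3 therefore stands not at a number but at the edge of what this assay can report: its entry is the limit of > 53400 nM in this assay, at which 1 of the 3 values shown sits. Compound 2 sits at a similar edge, (the limit of > 37900 nM in this assay, at which 1 of the 3 values shown sits). Only compound 1 carries a measured number, and that number is large on this scale. Nothing among these three compounds is measured as a step between structures that differ in one place, so no measured step can guide a prediction.

Compound 4 `COc1ccc(Oc2ccc(C(F)(F)F)cc2NC(=O)c2cc(=O)c3c(OC)cc(OC)cc3[nH]2)cc1` differs from compound 3 in a single way: 4-methoxyphenyl in place of 2-methoxyphenyl on an oxygen on an aromatic ring. The two compounds are built from the same atoms, joined differently, and the change touches only where the methoxy group sits on the phenoxy ring.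

Without a measured step, the expectation is that this change produces no shift beyond the usual scatter of this assay, with compound 4 expected to remain at a limit. The estimated step of a number no higher from compound 3 to compound 4 (the limit leaves the size open) is expected to be flat. Compound 4 is estimated at 53400 nM, expected to fall between 20000 nM and 120000 nM.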

Compound 4, half-maximal effective concentration: > 67200 nM
Compound 4 was reported as a limit (the forecaster's own chance of this, stated with the estimate: 75%); middle value at least 1.2-fold (0.09 log units) from the limit.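

Compound 3 and compound 4 are each reported in this assay only as a limit and not as a number, so the step between them cannot be read. The compounds shown leave open whether 4-methoxyphenyl in place of 2-methoxyphenyl changes the antiproliferative effect of this amide at all, and by how much.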